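The source may report more compounds than this note shows. Statements on the series, on what has been measured and on what is new or still open speak of the compounds shown alone.

Compound 1 `Cc1ccc(CNC2(CCC(C)(C)C)C(=O)C(C3=NS(=O)(=O)c4cc(NS(C)(=O)=O)ccc4N3)=C(O)c3ccccc32)cn1` stands lowest of the two half-life readings so far: in an in vivo ADME assay on the whole organism (strain Sprague-Dawley) for metabolic stability, with Rattus norvegicus as the target, at a dose of 5 mg/kg by the intravenous route (on this read-out lower numbers stand for a shorter-lived compound and higher numbers for a longer-lived compound), compound 1 gives 0.5 h, while compound 2 `CC(C)CC[C@@]1(NCc2ccccc2)C(=O)C(C2=NS(=O)(=O)c3cc(NS(C)(=O)=O)ccc3N2)=C(O)c2ccccc21`, which shares the core but differs in several places, gives 1.7 h in this assay, a gap beyond the scatter. Compound 3 `CC(C)(C)CCC1(NCc2ccc3ccccc3c2)C(=O)C(C2=NS(=O)(=O)c3cc(NS(C)(=O)=O)ccc3N2)=C(O)c2ccccc21` differs from compound 1 by a single change, (naphthalen-2-yl in place of 6-methylpyridin-3-yl on a saturated chain carbon bound to an amine nitrogen). No measured pair isolates this change, so nothing shown anchors its size; the step of a 1.2-fold higher number from compound 1 to compound 3 (0.08 log units; within the scatter) is expected to stay within the scatter. Compound 3 is therefore estimated at 0.6 h in this assay, with a range from 0.2 h to 1.5 h.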

Compound 3, half-life: 2.2 h
For compound 3 the middle estimate is 3.7-fold (0.56 log units) below the measured one; measured number above the stated range.
By their numbers in this assay, from the lowest: compound 1; then compounds 2 and 3 (each within the scatter of the next).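

In this assay the half-life moves (a 4.4-fold higher number from compound 1 to compound 3 (0.64 log units; beyond the scatter)) when naphthalen-2-yl replaces 6-methylpyridin-3-yl on a saturated chain carbon bound to an amine nitrogen, so this position is not indifferent to the group it carries. Among these compounds, this is the first change in one place that can be read here, and it lies beyond the scatter. Nothing available explains the step. Going by these compounds, whether the gain belongs to the second aromatic ring or to the loss of the ring nitrogen stays open. So does the effect of an amine or a carboxylic acid on the naphthalen-2-yl.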